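Acetyl to Propanoyl: From Compound 2 to Compound 3

The compounds below may be only part of what the source reports. "The series", "measured", "known", "first", "only" and "open" are said of these compounds alone.

Compound 1 `CC(=O)C1=C(O)C(C)(C)C(O)=C(CC2=C(O)C(C)(C)C(O)=C(C(C)=O)C2=O)C1=O` and compound 2 `CCC(=O)C1=C(O)C(C)(C)C(O)=C(Cc2c(O)c3c(c(C(C)=O)c2O)OC(C)(C)C=C3)C1=O` were tested in a functional assay on cells (Cancer cell lines, Homo sapiens) for cytotoxicity, with a stated time of 72 h; on this read-out higher numbers stand for an effect only at larger amounts of compound and lower numbers for an effect already at smaller amounts. Compound 1 gives > 50 ug/mL, which is a limit rather than a number (the limit of > 50 ug/mL in this assay, at which 1 of the 2 values shown sits). For the measured compounds named here, compound 2 gives 7 ug/mL, the only number among the two values shown. Compound 3 `CCC(=O)C1=C(O)C(C)(C)C(O)=C(Cc2c(O)c3c(c(C(=O)CC)c2O)OC(C)(C)C=C3)C1=O` differs from compound 2 by methyl in place of hydrogen on a saturated chain carbon bound to a carbonyl carbon. Going by the values given here, no measured pair differs in this one place alone, so the size of the step is unknown; it is expected to stay within the usual scatter of this assay. Compound 3 is therefore estimated at 6 ug/mL, with a range from 3 ug/mL to 14 ug/mL. That estimate means an expected 1.2-fold lower number from compound 2 to compound 3 (0.07 log units; within the scatter).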

Compound 3, concentration for half-maximal effect: 4.5 ug/mL
Compound 3: the middle estimate sits 1.3-fold (0.12 log units) above what was measured; low and high end bracket the measured number.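

The change from acetyl to propanoyl now has a measured size in this assay, a step of a 1.6-fold lower number from compound 2 to compound 3 (0.19 log units; within the scatter). With methyl in place of hydrogen on a saturated chain carbon bound to a carbonyl carbon, compound 2 and compound 3 therefore cannot be told apart on this read-out. Nothing measured here gives a reason for this step.

This single pair sets no trend for the position. Going by these compounds, the effect of a longer chain such as butanoyl, or of an amine or a carboxylic acid in this place, remains open.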